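Compound 4: a fluoro-methoxy aryl on the shared core

The compounds below may be only part of what the source reports. "The series", "measured", "known", "first", "only" and "open" are said of these compounds alone.

In a functional assay on KBVIN cells (Homo sapiens) for antiproliferative activity, read by sulforhodamine B assay, with a stated time of 3 days (a lower number here means that less compound is needed, a higher number that more compound is needed for the effect), compound 2 `CCC1=C(O)c2c(oc(-c3cccc(C)c3)cc2=O)C(CC)(CC)C1=O` gives 3.69 uM, the lowest of three numbers. Compound 3 `CCC1=C(O)c2c(oc(-c3cccc(C(F)(F)F)c3)cc2=O)C(CC)(CC)C1=O` gives 5.42 uM, and compound 1 `CCC1=C(O)c2c(oc(-c3ccc(CBr)cc3)cc2=O)C(CC)(CC)C1=O` gives 27.9 uM. The step of a 1.5-fold higher number from compound 2 to compound 3 (0.17 log units; within the scatter) stays within the scatter, whereas a 7.6-fold lower number from compound 1 to compound 2 (0.88 log units; beyond the scatter) was modest but beyond it. Compound 4 `CCC1=C(O)c2c(oc(-c3ccc(OC)c(F)c3)cc2=O)C(CC)(CC)C1=O` carries the change 3-fluoro-4-methoxyphenyl in place of 3-methylphenyl on an aromatic carbon on the shared core. Among the measured compounds shown here, only the step from compound 2 to compound 3 exchanges one group for another on the same aromatic carbon, and it moved little, so at most a modest step is expected in this assay, if anything toward a higher number. Compound 4 is therefore expected to give 4.5 uM in this assay, within 1.5 uM to 14 uM. The expected step is a 1.2-fold higher number from compound 2 to compound 4 (0.09 log units; within the scatter).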

Compound 4, concentration for half-maximal effect: 0.1 uM
Beside the measured number, compound 4's estimate is 45-fold (1.65 log units) above it; the measured number lies below the stated range.
By their numbers in this assay, from the lowest: compound 4; then compounds 2 and 3 (each within the scatter of the next); then compound 1.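

In this assay, the aryl group on the shared core proves able to move the number far more than the trifluoromethyl for methyl exchange did. With 3-fluoro-4-methoxyphenyl in place of 3-methylphenyl there is a 37-fold lower number from compound 2 to compound 4 (1.57 log units; beyond the scatter), and with it in place of 4-(bromomethyl)phenyl there is a 280-fold lower number from compound 1 to compound 4 (2.45 log units; beyond the scatter), so the earlier narrow spread does not hold for this change. On these data alone, it remains open whether the fluoro group, the methoxy group or the pair accounts for the drop, and whether an amine or a carboxylic acid on this aryl ring would keep it. No measurement available here explains the drop.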